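Diastereomeric tetrahydropyran lignans tested for cytotoxicity in HeLa cells

A few compounds are considered here, and "the series" means these few. Any claim that something is new, unique, unknown or untested is made for them only; others in the source may bear on it.

Measured so far:
Compound 1, `COc1ccc([C@@H]2OC[C@H]([C@@H](O)c3ccc(OC)c(OC)c3)C[C@H]2C/C=C/c2ccc(OC)c(OC)c2)cc1`: 29200 nM
Compound 2, `COc1ccc(/C=C/C[C@H]2C[C@@H]([C@@H](O)c3ccc(OC)c(OC)c3)CO[C@@H]2c2ccc(OC)c(OC)c2)cc1OC`: 23800 nM

Both compounds were tested in a functional assay on HeLa cells (Homo sapiens) for cytotoxicity, read by WST assay, with a stated time of 48 h; on this read-out lower numbers stand for stronger inhibition and higher numbers for weaker inhibition. In this assay compound 1 gives 29200 nM, and compound 2 gives 23800 nM. Compound 2 holds the lowest of the two numbers, but its nearest neighbour, compound 1, lies within the usual scatter of the measurement, so the two values cannot be set in order; both compounds are weak in this assay.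

The piece follows the step from compound 2 to compound 3, whose structure is `COc1ccc(/C=C/C[C@@H]2C[C@@H]([C@@H](O)c3ccc(OC)c(OC)c3)CO[C@H]2c2ccc(OC)c(OC)c2)cc1OC`. The change is the two compounds have the same atoms and bonds and differ only in configuration as drawn: 2 of 5 stereo elements differ; a stereocentre at a saturated ring carbon is drawn S in compound 2 and R in compound 3; a stereocentre at a saturated ring carbon is drawn S in compound 2 and R in compound 3

Among the compounds with values here, no step between two measured compounds is known here, so there is no pattern to lean on. Within the data shown here, the only guide is that compound 2 gives 23800 nM in this assay. A change of configuration at two ring stereocentres can move a value in either direction, but without a precedent the author expects no shift beyond the scatter, so the step of a 1.1-fold higher number from compound 2 to compound 3 (0.02 log units; within the scatter) is estimated as small. Compound 3 is therefore estimated at 25000 nM, with a range from 8000 nM to 80000 nM.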

Compound 3, half-maximal inhibitory concentration: 30600 nM
Compound 3: middle estimate off by 1.2-fold (0.09 log units), on the low side; the measured number falls inside the stated range.
By their numbers in this assay, from the lowest: compounds 2, 1 and 3 (each within the scatter of the next).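

In this assay, changing the configuration as drawn at two saturated ring stereocentres gives a 1.3-fold higher number from compound 2 to compound 3 (0.11 log units; within the scatter), so this change leaves no readable shift in cytotoxicity. The step with methoxy in place of hydrogen on an aromatic carbon, a 1.0-fold higher number from compound 1 to compound 3 (0.02 log units; within the scatter), likewise cannot be told from repeat measurements. Within the data shown here, the comparison of compound 2 with compound 3 is the first here to isolate stereochemistry, and it can be read as a test of configuration alone: the fact that compounds 2 and 3 differ only in the configuration as drawn.

The compounds shown leave open whether the other stereo elements, which are shared by compound 2 and compound 3, have any bearing on the read-out, and they give no step beyond the scatter against which a contribution from any part of the structure could be judged. They also leave open whether a free phenol or an amine in place of a methoxy group, or a carboxylic acid or longer chain on the shared core, would move the values away from the weak range in which all three compounds sit.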